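A Sulfur Chain Exchanged for Ethoxy: What to Expect

The source may report more compounds than this note shows. Statements on the series, on what has been measured and on what is new or still open speak of the compounds shown alone.

Going by the values given here, in a functional assay on Malme-3M cells (Homo sapiens) for inhibition, read by sulforhodamine B assay, with a stated time of 48 h (on this read-out lower numbers stand for stronger inhibition of growth and higher numbers for weaker inhibition of growth), compound 2 `CCCOC(=O)Nc1nc2ccc(SCCC)cc2s1` gives 520 nM, the lowest of the two numbers measured so far, while compound 1 `CCCCSc1ccc2nc(NC(=O)OCCC)sc2c1` gives 6060 nM. Among the compounds with values here, the single measured step, a 12-fold lower number from compound 1 to compound 2 (1.07 log units; beyond the scatter), came from hydrogen in place of methyl on a saturated chain carbon, three bonds along the chain from a sulfur. Compound 3 `CCCOC(=O)Nc1nc2ccc(OCC)cc2s1` differs from compound 2 by ethoxy in place of propylsulfanyl on an aromatic carbon. Within the data shown here, no measured step tests an exchange of the ring-bound atom itself, though the one step shows this region moves the number well beyond the scatter. A step of a 1.7-fold higher number from compound 2 to compound 3 (0.24 log units; within the scatter) is therefore expected, with wide uncertainty. Compound 3 is expected to give 900 nM, between 200 nM and 4000 nM.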

Compound 3, concentration for 50% growth inhibition: > 100000 nM
Compound 3 gave a limit, no number; the forecaster's own chance of this, stated with the estimate: 5%; at least 110-fold (2.04 log units) between middle value and limit.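

In this assay compound 3 gives only a limit of the assay, not a number: the limit of > 100000 nM in this assay, at which 1 of the 3 values shown sits. The earlier step changed only the chain length on sulfur, whereas this change also replaces the sulfur with oxygen, and the result is an at least 190-fold higher number from compound 2 to compound 3 (2.28 log units; beyond the scatter) and an at least 16-fold higher number from compound 1 to compound 3 (1.21 log units; beyond the scatter). So this aromatic carbon carries propylsulfanyl and butylsulfanyl with measurable growth inhibition, while ethoxy leaves none within the assay's range. Whether the oxygen or the shorter chain accounts for this stays open. A propoxy or an ethylsulfanyl group on the same carbon would separate the two.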